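This account rests on a few compounds, and the source may have more. Where it says the series, first, only, none or still open, it means among the compounds named here.

Measured compounds:
compound 1, `COc1ccc(/C=C2/C(=O)N(c3ccc(Cl)cc3)N=C2C)c(OC)c1OC`, 2100 nM
compound 2, `CC1=NN(c2ccc(Cl)cc2)C(=O)/C1=C/c1ccc(Br)cc1`, 1920 nM

Among the compounds with values here, in an assay for inhibition of Alpha amylase (Homo sapiens), with a stated time of 10 min (on this read-out higher numbers stand for weaker inhibition and lower numbers for stronger inhibition), compound 2 gives 1920 nM, while compound 1 gives 2100 nM; the two values lie within the scatter of each other, so compound 2 stands level with the only other measured compound. Compound 3, `CC1=NN(c2ccc(Cl)cc2)C(=O)/C1=C/c1ccc([N+](=O)[O-])cc1`, differs from compound 2 by nitro in place of bromo on an aromatic carbon. Within the data shown here, no step between measured compounds covers this exchange, so no step beyond the scatter is expected in this assay, in either direction. Compound 3 is therefore expected to give about 2000 nM, with a range from 700 nM to 6000 nM. This expectation amounts to a step of a 1.0-fold higher number from compound 2 to compound 3 (0.02 log units; within the scatter).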

Compound 3, half-maximal inhibitory concentration: 2380 nM
Compound 3: middle estimate off by 1.2-fold (0.08 log units), on the low side; the measured number falls inside the stated range.
By their numbers in this assay, from the lowest: compounds 2, 1 and 3 (each within the scatter of the next).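

In this assay, within the data shown here, nitro in place of bromo on an aromatic carbon, para to a large group, gives a 1.2-fold higher number from compound 2 to compound 3 (0.09 log units; within the scatter), the first step that can be read at this position. Nitro brings more heavy atoms and hydrogen-bond acceptors than bromo, yet the exchange produces no step beyond the scatter. Nothing measured here speaks to why compound 2 and compound 3 stand level. 

Going by these compounds, whether an amine or a carboxylic acid at this position would also stay level remains open. So does whether a hydroxyl or a longer chain there would move the number beyond the scatter.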